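Removing the N-aryl group from a weakly active quinolinyl benzoxazinone

A few compounds are considered here, and "the series" means these few. Any claim that something is new, unique, unknown or untested is made for them only; others in the source may bear on it.

Measured so far:
- compound 1 `COc1ncc(-c2ccc3c(c2)N(c2ccc(C)cc2)C(=O)CO3)cc1NS(=O)(=O)c1ccc(F)cc1`, 15400 nM
- compound 2 `Cc1ccc(N2C(=O)COc3ccc(-c4cnc5ccccc5c4)cc32)cc1`, > 40000 nM
- compound 3 `O=C1COc2ccc(-c3ccc(O)cc3)cc2N1`, > 40000 nM

The three compounds share a fused bicyclic core carrying an aryl substituent, and all were tested in a functional assay on MCF7 cells (Homo sapiens) for antiproliferative activity, read by MTT assay, with a stated time of 72 h; a higher number here means a weaker inhibitor, a lower number a stronger inhibitor. Compound 1 gives 15400 nM. For compound 2 the reading of > 40000 nM is a limit of the assay and not a number. For compound 3 the reading of > 40000 nM is likewise a limit of the assay. Among the values shown, compound 2 therefore stands at the limit of > 40000 nM in this assay, at which 2 of the 3 values shown sit.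

Compound 4 `O=C1COc2ccc(-c3cnc4ccccc4c3)cc2N1` has not been measured in this assay. It differs from compound 2 by hydrogen in place of 4-methylphenyl on an amide-type nitrogen in a ring. Since compound 2 sits at a limit, and compound 3, which also carries a hydrogen on the amide-type nitrogen, sits at the same limit, a step of no discernible size is expected, with compound 4 expected to remain at or near the limit as a number no higher from compound 2 to compound 4 (the limit leaves the size open). Compound 4 is estimated at 40000 nM, within 20000 nM to 80000 nM.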

Compound 4, half-maximal inhibitory concentration: > 40000 nM
Compound 4 ended at the assay's limit (the forecaster's own chance of this, stated with the estimate: 75%); the middle value lies on the limit itself.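

For the compounds shown here, compound 2 and compound 4 both read only as limits in this assay, not as numbers, so no step between them can be read. The compounds shown leave open whether hydrogen in place of 4-methylphenyl on this amide-type nitrogen changes antiproliferative activity at all.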